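Chloro substitution and Vero tolerance in the aminopyrazole amidine series

The source may report more compounds than this note shows. Statements on the series, on what has been measured and on what is new or still open speak of the compounds shown alone.

Three compounds on a shared core are measured in an ADME assay on Vero cells (Chlorocebus sabaeus) for cytotoxicity, read by CellTiter-Glo and ATP content, with a stated time of 72 h; a higher number here means that more compound is tolerated, a lower number that less compound is tolerated. Compound 1 `Nc1c(C2=NCCN2)cnn1-c1ccc(Cl)c(Cl)c1` gives 244000 nM. Compound 2 `Nc1c(C2=NCCN2)cnn1-c1ccc(Cl)cc1` returns only the limit > 500000 nM. Compound 3 `Nc1c(C2=NCCCN2)cnn1-c1ccccc1` likewise returns only the limit > 500000 nM. Two of the three values thus sit at the same boundary, (the limit of > 500000 nM in this assay, at which 2 of the 3 values shown sit). The difference between the cores of compound 2 and compound 3 is not broken down here.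

From compound 2 to compound 1 the change is chloro in place of hydrogen on an aromatic carbon, and the step is an at least 2.0-fold lower number from compound 2 to compound 1 (0.31 log units; beyond the scatter). Compound 4 `Nc1c(C2=NCCCN2)cnn1-c1cccc(Cl)c1`, not yet measured, carries the same kind of change relative to compound 3, (chloro in place of hydrogen on an aromatic carbon); here the entering chloro is not ortho to a chloro group, only meta to a large group. Given the step from compound 2 to compound 1 an at least 2.0-fold lower number from compound 2 to compound 1 (0.31 log units; beyond the scatter), compound 4 is expected to fall somewhat, by about an at least 1.4-fold lower number from compound 3 to compound 4 (0.15 log units; that floor lies within the scatter), in this assay, though the starting point is a limit. The estimate for compound 4 is 350000 nM, between 150000 nM and 500000 nM.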

Compound 4, half-maximal cytotoxic concentration: > 500000 nM
Compound 4: only a limit was reported; the forecaster's own chance of this, stated with the estimate: 45%; middle value at least 1.4-fold (0.15 log units) from the limit.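

Compound 4 returns only a limit, > 500000 nM, in this assay. With compound 3 also at a limit, no step between compound 3 and compound 4 can be read: the limit of > 500000 nM in this assay, at which 3 of the 4 values shown sit.

Going by these compounds, whether chloro in place of hydrogen on an aromatic carbon changes tolerance on the core of compound 3 stays open.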